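The source may report more compounds than this note shows. Statements on the series, on what has been measured and on what is new or still open speak of the compounds shown alone.

Measured compounds:
compound 1, `O=C(Nc1nc2ccc(F)cc2s1)c1cn(-c2ccccc2)nc1-c1ccccc1`, 3250 nM
compound 2, `O=C(Nc1nc2ccc(Cl)cc2s1)c1cn(-c2ccccc2)nc1-c1ccccc1`, 3690 nM
compound 3, `O=C(Nc1nc2ccc(F)cc2s1)c1cn(-c2ccccc2)nc1-c1ccc(Cl)cc1`, 5790 nM

All three were tested in a functional assay on PC-3 cells (Homo sapiens) for cytotoxicity, read by MTT assay, with a stated time of 72 h; a lower number here means a stronger inhibitor, a higher number a weaker inhibitor. In this assay compound 1 gives 3250 nM, compound 2 gives 3690 nM and compound 3 gives 5790 nM. The unmeasured compound 4 is `O=C(Nc1nc2ccc(Cl)cc2s1)c1cn(-c2ccccc2)nc1-c1ccc(Cl)cc1`.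

Compound 1 and compound 2 differ in one place: chloro in place of fluoro on an aromatic carbon This change gave a 1.1-fold higher number from compound 1 to compound 2 (0.06 log units; within the scatter), so the two numbers lie within the ordinary spread of repeated measurements and no real difference between them can be claimed.

Compound 3 carries a different core from compound 1; the two cores differ in one place: chloro in place of hydrogen on an aromatic carbon The step there was a 1.8-fold higher number from compound 1 to compound 3 (0.25 log units; within the scatter), again within the spread.

Compound 4 is related to compound 3 by the same change that relates compound 1 to compound 2: chloro in place of fluoro on an aromatic carbon The surroundings of the place are described in identical words in both pairs, so it is the same change on a core that differs only by the chloro on the phenyl ring.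

Because the earlier instance of this change gave a 1.1-fold higher number from compound 1 to compound 2 (0.06 log units; within the scatter), the step from compound 3 to compound 4 is expected to be of similar size, about a 1.1-fold higher number from compound 3 to compound 4 (0.05 log units; within the scatter). Compound 4 is therefore estimated at 6500 nM in this assay, with a likely range from 3000 nM to 14000 nM. This rests on a single earlier instance, so the estimate is loose.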

Compound 4, half-maximal inhibitory concentration: 3230 nM
Compound 4: the middle estimate sits 2.0-fold (0.30 log units) above what was measured, and the stated range covers the measured number.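

In this assay, going from 6-fluoro-1,3-benzothiazol-2-yl to 6-chloro-1,3-benzothiazol-2-yl on the core with the extra chloro on the phenyl ring gave a 1.8-fold lower number from compound 3 to compound 4 (0.25 log units; within the scatter), and this step does not differ meaningfully from the earlier instance of the same change: the same change on two cores in this assay, a 1.1-fold higher number (0.06 log units; within the scatter) from compound 1 to compound 2 and a 1.8-fold lower number (0.25 log units; within the scatter) from compound 3 to compound 4, 2.0-fold (0.31 log units) apart, within the scatter of two such steps

Placing chloro instead of hydrogen on the phenyl ring, now with the 6-chloro group already present, gave a 1.1-fold lower number from compound 2 to compound 4 (0.06 log units; within the scatter), and this too agrees with its earlier instance: the same change on two cores in this assay, a 1.8-fold higher number (0.25 log units; within the scatter) from compound 1 to compound 3 and a 1.1-fold lower number (0.06 log units; within the scatter) from compound 2 to compound 4, 2.0-fold (0.31 log units) apart, within the scatter of two such steps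

Within these four compounds, each change therefore looks the same on both cores, with every step inside the ordinary spread of repeated measurements, but this does not show that either change carries over reliably: each comparison rests on just one pair of steps, and a real effect smaller than the scatter would go unseen.

The compounds shown leave open whether a different kind of group, such as an amine, a carboxylic acid or a methoxy group, would move the number beyond the scatter at the place now held by fluoro or chloro. They also leave open whether a larger step of that kind would carry from one core to the other as consistently as these small ones appear to.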